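The source may report more compounds than this note shows. Statements on the series, on what has been measured and on what is new or still open speak of the compounds shown alone.

Working notes on the series. Compound 2 `CCSC(=S)SCC(=O)c1cccc(C(=O)Nc2ccccc2)c1` gives 2400 nM in a functional assay on HeLa cells (Homo sapiens) for cytotoxicity, read by resazurin assay, with a stated time of 72 h; a lower number here means a stronger inhibitor, a higher number a weaker inhibitor. Compound 1 `CCSC(=S)SCC(=O)c1cccc(C(=O)NCc2ccccc2)c1` carries benzyl in place of phenyl on an amide-type nitrogen and in this assay compound 1 gives 13100 nM, so that a 5.5-fold higher number from compound 2 to compound 1 (0.74 log units; beyond the scatter). Compound 3 `CCSC(=S)SCC(=O)c1ccc(C(=O)Nc2ccccc2)cc1` has the same atoms as compound 2 joined differently; the difference between the two cores is not broken down here. In this assay compound 3 gives 25800 nM, the highest of the three numbers, though its gap to compound 1 lies within the scatter. Compound 4 `CCSC(=S)SCC(=O)c1ccc(C(=O)NCc2ccccc2)cc1` is not yet measured; it carries benzyl in place of phenyl on an amide-type nitrogen, the same kind of change as that from compound 2 to compound 1, at a place described in the same words. Resting on the step of a 5.5-fold higher number from compound 2 to compound 1 (0.74 log units; beyond the scatter), the step to compound 4 is expected to be a 4.3-fold higher number from compound 3 to compound 4 (0.63 log units; beyond the scatter). Compound 4 is thus estimated at 110000 nM, between 35000 nM and 350000 nM.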

Compound 4, half-maximal inhibitory concentration: 23900 nM
Estimate against measurement, compound 4: 4.6-fold (0.66 log units) above; measured number below the stated range.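

Benzyl in place of phenyl on an amide-type nitrogen does not carry over from one core to the other in this assay: the same change on two cores in this assay, a 5.5-fold higher number (0.74 log units; beyond the scatter) from compound 2 to compound 1 and a 1.1-fold lower number (0.03 log units; within the scatter) from compound 3 to compound 4, 5.9-fold (0.77 log units) apart, beyond the scatter of two such steps

On the core of compound 3 the step is a 1.1-fold lower number from compound 3 to compound 4 (0.03 log units; within the scatter), so the rise seen on the core of compound 2 does not recur there. These two pairs show that the size of this step depends on the core, but they do not show which feature of the cores sets the two steps apart, or how the change would read on any further core.

Open, on these data alone, is how a longer chain such as phenethyl, in place of benzyl on the amide-type nitrogen, would read on either core. Also open, as far as these compounds go, is whether an amine or a carboxylic acid carried on the benzyl group would leave the two cores as far apart.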